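Hydroxyphenyl placement on two pyridylpyridine cores and cytotoxicity

A few compounds are considered here, and "the series" means these few. Any claim that something is new, unique, unknown or untested is made for them only; others in the source may bear on it.

Measured compounds:
compound 1 `Oc1cccc(-c2cc(-c3ccccn3)cc(-c3ccccc3O)n2)c1`: 2020 nM
compound 2 `Oc1ccc(-c2cc(-c3ccccn3)cc(-c3ccccc3O)n2)cc1`: > 50000 nM
compound 3 `Oc1cccc(-c2cc(-c3cccnc3)cc(-c3cccc(O)c3)n2)c1`: > 50000 nM

Of the compounds shown here, three have been tested in a functional assay on HeLa cells (Homo sapiens) for cytotoxicity, read by CCK-8 assay; on this read-out lower numbers stand for stronger inhibition and higher numbers for weaker inhibition. Compound 1 gives 2020 nM. For compound 2 the assay reports only a limit, > 50000 nM. For compound 3, likewise, only a limit is reported, > 50000 nM. For the measured compounds named here, the one counted step is 4-hydroxyphenyl in place of 3-hydroxyphenyl on an aromatic carbon, which produced an at least 24-fold higher number from compound 1 to compound 2 (1.39 log units; beyond the scatter); two of the three values sit at the same limit (the limit of > 50000 nM in this assay, at which 2 of the 3 values shown sit).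

Compound 4 `Oc1ccc(-c2cc(-c3cccnc3)cc(-c3cccc(O)c3)n2)cc1` is not yet measured. It differs from compound 3 by 4-hydroxyphenyl in place of 3-hydroxyphenyl on an aromatic carbon. How the core of compound 3 differs from that of compound 1 is not broken down here. The surroundings of the place also differ: in compound 1 the place is meta to a 2-hydroxyphenyl group and meta to a pyridin-2-yl group, whereas in compound 3 it is meta to a 3-hydroxyphenyl group and meta to a pyridin-3-yl group, so the change is of the same kind rather than the same. The step from compound 3 is expected to be a step that the limit leaves unreadable from compound 3 to compound 4, resting on the starting limit of compound 3 at > 50000 nM and on the weakening seen in an at least 24-fold higher number from compound 1 to compound 2 (1.39 log units; beyond the scatter). In this assay compound 4 is expected to give 100000 nM, between 50000 nM and 300000 nM.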

Compound 4, half-maximal inhibitory concentration: > 50000 nM
Compound 4: a limit, no number; the forecaster's own chance of this, stated with the estimate: 85%; the middle value is on the limit's open side.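

Compound 4 gives only a limit in this assay, > 50000 nM. No step can be read from compound 3 to compound 4 because both values are limits: the limit of > 50000 nM in this assay, at which 3 of the 4 values shown sit.

The compounds shown leave open whether 4-hydroxyphenyl in place of 3-hydroxyphenyl changes cytotoxicity at all on the core of compound 3.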